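This account rests on a few compounds, and the source may have more. Where it says the series, first, only, none or still open, it means among the compounds named here.

In an ADME assay on CCRF-CEM cells (Homo sapiens) for cytotoxicity (on this read-out higher numbers stand for weaker inhibition and lower numbers for stronger inhibition), compound 1 (`Nc1nc(Cl)c2ncn([C@@H]3O[C@H](CO)C=C3F)c2n1`) gives 30200 nM; > 100000 nM (2 entries). In this assay compound 2 (`Nc1nc(N)c2ncn([C@@H]3O[C@H](CO)C=C3F)c2n1`) gives only > 100000 nM as a limit of the assay, not a number, so its true position is not pinned down. Compound 3 (`Nc1nc(N)c2ncn([C@@H]3O[C@@H](CO)C=C3F)c2n1`) has the same atoms and bonds as compound 2 and differs only in configuration as drawn (the two compounds have the same atoms and bonds and differ only in configuration as drawn: 1 of 2 stereo elements differ; a stereocentre at a saturated ring carbon is drawn S in compound 2 and R in compound 3). Among the compounds with values here, with no measured step to lean on, the expected a number no higher from compound 2 to compound 3 (the limit leaves the size open) in this assay is none beyond the usual scatter. The estimate for compound 3 is 100000 nM with an expected range from 40000 nM to 150000 nM on this read-out.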

Compound 3, half-maximal inhibitory concentration: > 100000 nM
Compound 3 ended at the assay's limit; the forecaster's own chance of this, stated with the estimate: 85%; the middle value sits exactly at the limit.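

Within the data shown here, compound 2 and compound 3 both end at a limit of this assay, and no step between them can be read. The compounds shown leave open whether the configuration at that saturated ring carbon changes this read-out at all.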